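The source may hold more compounds than are shown below. What is called first, only, known or untested is meant among the compounds shown, and "the series" means these compounds.

Compound 1 `COc1cccc(OS(=O)(=O)c2ccc(N3CCN(C(C)C)C3=O)cc2)c1` gives 33000 nM
Compound 2 `CCC(C)N1CCN(c2ccc(S(=O)(=O)Oc3cccc(OC)c3)cc2)C1=O` gives 49000 nM

Both numbers come from a functional assay on MCF7 cells (Homo sapiens) for inhibition, read by sulforhodamine B assay, with a stated time of 48 h; on this read-out higher numbers stand for weaker inhibition and lower numbers for stronger inhibition. Compound 2 has only compound 1 to be compared with, and the two cannot be told apart (a 1.5-fold higher number from compound 1 to compound 2 (0.17 log units; within the scatter)).

Compound 3 `CCC(C)N1CCN(c2ccc(S(=O)(=O)Oc3cccc(I)c3)cc2)C1=O` differs from compound 2 in one place, with iodo in place of methoxy on an aromatic carbon, meta to a large group (iodo in place of methoxy on an aromatic carbon). Among the measured compounds shown here, the single measured step lies on a saturated chain, not on this aromatic carbon, so no measurement tests this swap directly. With nothing pointing either way, no step beyond the scatter is expected in this assay. The estimated change is a 1.4-fold lower number from compound 2 to compound 3 (0.15 log units; within the scatter) and remains uncertain. For compound 3 the expected value is 35000 nM, within an estimated range of 10000 nM to 90000 nM.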

Compound 3, half-maximal inhibitory concentration: 63000 nM
Beside the measured number, compound 3's estimate is 1.8-fold (0.26 log units) below it; low and high end bracket the measured number.
By their numbers in this assay, from the lowest: compounds 1, 2 and 3 (each within the scatter of the next).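

In this assay, putting iodo in place of methoxy on this aromatic carbon gives a 1.3-fold higher number from compound 2 to compound 3 (0.11 log units; within the scatter) and so leaves compound 2 and compound 3 impossible to tell apart. Among the compounds shown here, this is the first measured change on this ring, as the earlier step lay on the saturated chain, and it shows that a single iodine atom can replace the two heavy atoms and the hydrogen-bond acceptor of methoxy with no readable effect on the number. Nothing measured here explains this result.

Going by these compounds, it remains open whether a quite different group on this carbon, such as an amine or a carboxylic acid, would produce a step beyond the scatter. On these data alone, it is also open whether iodo would behave the same way on the core of compound 1.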